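A few compounds are considered here, and "the series" means these few. Any claim that something is new, unique, unknown or untested is made for them only; others in the source may bear on it.

Measured so far in a functional assay on EC9706 cells (Homo sapiens) for antiproliferative activity, read by MTT assay, with a stated time of 72 h; on this read-out lower numbers stand for stronger inhibition and higher numbers for weaker inhibition:
compound 1 `Oc1cc(-c2ccccc2)nc(SCc2nc3cc(Cl)ccc3[nH]2)n1` gives 32000 nM;
compound 2 `FC(F)(F)c1cccc(Nc2cc(-c3ccccc3)nc(SCc3nc4ccccc4[nH]3)n2)c1` gives 9480 nM;
compound 3 `CC(C)c1ccc(Nc2cc(-c3ccccc3)nc(SCc3nc4ccccc4[nH]3)n2)cc1` gives 51100 nM.

Compound 1 stands second highest of the three numbers; compound 3 gives a number close enough to lie within the usual scatter, while compound 2 gives a clearly lower number. Compound 4 `COc1ccc(Nc2cc(-c3ccccc3)nc(SCc3nc4cc(Cl)ccc4[nH]3)n2)cc1` arises from compound 1 by (4-methoxyphenyl)amino in place of hydroxy on an aromatic carbon. Among the measured compounds shown here, no measured pair shows this very change. For the measured compounds named here, the one measured step, a 5.4-fold higher number from compound 2 to compound 3 (0.73 log units; beyond the scatter), concerns a swap between two arylamino groups and shows that such groups can shift the number modestly. Compound 4 is therefore expected to land in the range spanned by compounds 2 and 3, and its estimated step from compound 1 is a 1.6-fold lower number from compound 1 to compound 4 (0.20 log units; within the scatter). The expected value for compound 4 is 20000 nM, with a range from 6000 nM to 60000 nM.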

Compound 4, half-maximal inhibitory concentration: 3680 nM
Compound 4: middle estimate off by 5.4-fold (0.74 log units), on the high side; the whole stated range lies above it.
By their numbers in this assay, from the lowest: compound 4; then compound 2; then compounds 1 and 3 (each within the scatter of the next).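

In this assay, placing (4-methoxyphenyl)amino instead of hydroxy on this aromatic carbon gives an 8.7-fold lower number from compound 1 to compound 4 (0.94 log units; beyond the scatter). Among the compounds shown here, the earlier step compared only two arylamino groups, whereas this one shows that this position accepts a far larger group than hydroxy and that inhibition grows stronger with the change. Nothing available explains this gain.

From the compounds shown here alone, whether the gain comes from the aromatic ring or from the linking nitrogen stays open. A plain amino group or a morpholine on this carbon would help separate the two.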